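Series notes: amine tail variation on the shared core

The source may hold more compounds than are shown below. What is called first, only, known or untested is meant among the compounds shown, and "the series" means these compounds.

Among the measured compounds shown here, compound 2 `NCCCCOc1ccc([C@H]2CC[C@]3(CC2)OOC2(O3)C3CC4CC(C3)CC2C4)cc1` gives 4700 ng.h/mL in an ADME assay on the whole organism (strain FVB) for pharmacokinetics, with Mus musculus as the target, read by LC-MS, at a dose of 30 mg/kg by the oral route (a lower number here means less compound in the circulation, a higher number more compound in the circulation at the dose given), the lowest of the two numbers so far. The nearest point is compound 1 `N[C@H]1CC[C@@H](Oc2ccc([C@H]3CC[C@]4(CC3)OOC3(O4)C4CC5CC(C4)CC3C5)cc2)CC1`, which gives 13400 ng.h/mL in this assay. For the measured compounds named here, the gap between them is the single measured step in the set, a 2.9-fold lower number from compound 1 to compound 2 (0.46 log units; beyond the scatter), and it is the only guidance available for the next change.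

Compound 3 `c1cc([C@H]2CC[C@]3(CC2)OOC2(O3)C3CC4CC(C3)CC2C4)ccc1OCCOC1CCNCC1` is built from compound 2 by one exchange: (piperidin-4-yl)oxy in place of 2-aminoethyl on a saturated chain carbon, two bonds along the chain from an oxygen on an aromatic ring. Going by the values given here, the one step that bears on it, a 2.9-fold lower number from compound 1 to compound 2 (0.46 log units; beyond the scatter), runs from a ring-bearing tail to an open chain and lowered the number by a modest amount. The present change moves part of the tail back into a ring, though not the same ring and not at the same point of the chain, so the direction is taken from that step with caution. A rise rather than a fall is expected in this assay, and the step expected for compound 3, a 1.4-fold higher number from compound 2 to compound 3 (0.14 log units; within the scatter), is kept small enough that it may sit within the scatter. Compound 3 is estimated at 6500 ng.h/mL in this assay, with a range from 2500 ng.h/mL to 16000 ng.h/mL.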

Compound 3, area under the concentration-time curve in the Mus musculus assay: 9180 ng.h/mL
Compound 3: middle estimate off by 1.4-fold (0.15 log units), on the low side; the range from low to high includes it.
By their numbers in the Mus musculus assay, from the lowest: compounds 2, 3 and 1 (each within the scatter of the next, the first and the last beyond it).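

In the Mus musculus assay the exchange at this place, on a saturated chain carbon two bonds along the chain from an oxygen on an aromatic ring, gives a 2.0-fold higher number from compound 2 to compound 3 (0.29 log units; within the scatter), so a larger tail with its amine held in a six-membered non-aromatic ring is accommodated without a step beyond the scatter, and the comparison with the ring-bearing tail, a 1.5-fold lower number from compound 1 to compound 3 (0.16 log units; within the scatter), also stays within it. In a physicochemical assay for solubility, read by nephelometry, measured as kinetic solubility, with a stated time of 30 min (a higher number here means a more soluble compound, a lower number a less soluble compound), compound 2 gives 50 ug/mL and compound 3 gives 50 ug/mL, and the step reads no change at the digits printed from compound 2 to compound 3 (within the scatter), so this exchange leaves that read-out where it was at the digits printed. No measurement at hand accounts for any of these numbers.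

On these data alone, the oxygen and the ring of (piperidin-4-yl)oxy enter together, and the share of each in the result remains open. Also open, as far as these compounds go, is how a tertiary amine or an amide in place of the amine of this tail would read in the Mus musculus assay and in the physicochemical assay.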